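A few compounds are considered here, and "the series" means these few. Any claim that something is new, unique, unknown or untested is made for them only; others in the source may bear on it.

Measured compounds in a functional assay on cardiac atrium for agonist activity at histamine H2 receptor (Cavia porcellus); on this read-out lower numbers stand for lower potency and higher numbers for higher potency (the scale is a negative logarithm):
compound 1 `N=C(NCCCc1c[nH]cn1)NCCC(c1ccccc1)c1ccccn1`: 7.39
compound 2 `N=C(NCCCc1c[nH]cn1)NCCC(c1ccc(Br)cc1)c1ccccn1`: 7.48
compound 3 `N=C(NCCCc1c[nH]cn1)NCCC(c1cccc(C(F)(F)F)c1)c1ccccn1`: 7.43

The three measured compounds share one core and differ only in the aryl group carried on the saturated chain carbon. In this assay compound 3 stands second highest of the three numbers, but its neighbours sit close on both sides: the step of a number 0.04 log units higher from compound 1 to compound 3 (within the scatter) and the step of a number 0.05 log units lower from compound 2 to compound 3 (within the scatter) both fall within the scatter, as does the step of a number 0.09 log units higher from compound 1 to compound 2 (within the scatter). On the numbers shown, none of the three aryl variations can be told apart.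

Compound 4 `N=C(NCCCc1c[nH]cn1)NCCC(c1ccccn1)c1ccccc1F` differs from compound 3 in a single place: 2-fluorophenyl in place of 3-(trifluoromethyl)phenyl on a saturated chain carbon bound to an aromatic carbon and a saturated chain carbon. Going by the values given here, the steps that bear on this change are the aryl swap a number 0.05 log units lower from compound 2 to compound 3 (within the scatter) and the substitution a number 0.04 log units higher from compound 1 to compound 3 (within the scatter), both within the scatter. A change of the same kind, exchanging one substituted phenyl for another on the same chain carbon, is therefore expected to give no step beyond the scatter; the expected step is a number 0.03 log units lower from compound 3 to compound 4 (within the scatter). On that basis compound 4 is estimated to give 7.4 in this assay, with a range from 7 to 7.8.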

Compound 4, negative logarithm of the half-maximal effective concentration: 7.46
Compound 4: middle estimate off by 0.06 log units, on the low side; measured number inside the range.
By their numbers in this assay, from the lowest: compounds 1, 3, 4 and 2 (each within the scatter of the next).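

In this assay, the step for putting a fluoro substituent on the unsubstituted phenyl group is a number 0.07 log units higher from compound 1 to compound 4 (within the scatter), and so a substituent is added at this place with no step beyond the scatter. The exchanges between substituted phenyl groups read the same way: a number 0.03 log units higher from compound 3 to compound 4 (within the scatter) is the step for 2-fluorophenyl replacing 3-(trifluoromethyl)phenyl, and a number 0.02 log units lower from compound 2 to compound 4 (within the scatter) is the step for 2-fluorophenyl replacing 4-bromophenyl. The saturated chain carbon bound to an aromatic carbon and a saturated chain carbon therefore now carries 2-fluorophenyl as well as 3-(trifluoromethyl)phenyl, and all four compounds remain within the scatter of one another, while no measurement given here offers an explanation for this flat picture.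

The compounds shown leave open whether an amino group or a carboxylic acid on the phenyl ring would give a step beyond the scatter at this place. They also leave open whether a cyclohexyl group in place of the phenyl ring, or a difluorophenyl group, would separate from these four compounds.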